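The source may report more compounds than this note shows. Statements on the series, on what has been measured and on what is new or still open speak of the compounds shown alone.

Measured compounds:
- compound 1 `Fc1cc2nc(-c3cncnc3)n(C3CC3)c2cc1F`: 2270 nM
- compound 2 `CNc1ncncc1-c1nc2cc(F)c(F)cc2n1C1CC1`: 390 nM

Within the data shown here, in an ADME assay on cells for inhibition of cytochrome P450 11B1, mitochondrial (Homo sapiens), read by HPLC, with a stated time of 60 min (on this read-out lower numbers stand for stronger inhibition and higher numbers for weaker inhibition), compound 2 gives the lower of the two numbers, the only other measured compound being compound 1, which gives 2270 nM. Among the measured compounds shown here, the one measured step, a 5.8-fold lower number from compound 1 to compound 2 (0.76 log units; beyond the scatter), shows methylamino in place of hydrogen on an aromatic carbon. Compound 3 `CN(C)c1ncncc1-c1nc2cc(F)c(F)cc2n1C1CC1` carries methyl in place of hydrogen on a nitrogen on an aromatic ring. For the measured compounds named here, no measured step bears directly on adding a methyl to that nitrogen, so the direction is uncertain. The step of a 1.5-fold higher number from compound 2 to compound 3 (0.19 log units; within the scatter) is expected to be small. Compound 3 is estimated at 600 nM, within 150 nM to 2500 nM.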

Compound 3, half-maximal inhibitory concentration: 4630 nM
For compound 3 the middle estimate is 7.7-fold (0.89 log units) below the measured one; measured number above the stated range.
By their numbers in this assay, from the lowest: compound 2; then compound 1; then compound 3.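

In this assay, the nitrogen carrying methylamino proves sensitive to a further methyl: the change to dimethylamino gives a 12-fold higher number from compound 2 to compound 3 (1.07 log units; beyond the scatter). This more than cancels the gain that methylamino brought, since dimethylamino in place of hydrogen on the aromatic carbon gives a 2.0-fold higher number from compound 1 to compound 3 (0.31 log units; beyond the scatter). Nothing available explains this reversal. The compounds shown leave open whether the plain amine would match methylamino, and whether a longer chain such as ethylamino on that nitrogen would keep the lower number or lose it as dimethylamino does.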